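From thiophen-2-yl to 1H-benzimidazol-2-yl on the shared core

This account rests on a few compounds, and the source may have more. Where it says the series, first, only, none or still open, it means among the compounds named here.

Measured in a functional assay on NCI-H460 cells (Homo sapiens) for cytotoxicity, read by MTT assay, with a stated time of 72 h (a lower number here means a stronger inhibitor, a higher number a weaker inhibitor), so far:
compound 1 `O=c1[nH]/c(=C\c2ccco2)c(=O)[nH]/c1=C\c1cccc(Oc2ccc(F)cc2)c1` gives 155 nM as a number
compound 2 `O=c1[nH]/c(=C\c2cccs2)c(=O)[nH]/c1=C\c1cccc(Oc2ccc(F)cc2)c1` gives > 1000 nM as a limit

Compound 2 stands only at a limit in this assay and has no number. Compound 3 `O=c1[nH]/c(=C\c2nc3ccccc3[nH]2)c(=O)[nH]/c1=C\c1cccc(Oc2ccc(F)cc2)c1` carries 1H-benzimidazol-2-yl in place of thiophen-2-yl on a double-bonded chain carbon bound to an aromatic carbon on a double-bonded chain carbon bound to an aromatic carbon. Going by the values given here, the only measured step at this place is an at least 6.4-fold higher number from compound 1 to compound 2 (0.80 log units; beyond the scatter) and it lies beyond the scatter, so a change of group here is expected to move the number, probably lower, by an uncertain amount. The estimated step is an at least 1.4-fold lower number from compound 2 to compound 3 (0.15 log units; that floor lies within the scatter) and it remains loose. In this assay compound 3 is expected near 700 nM with 120 nM to 3000 nM as its estimated range.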

Compound 3, half-maximal inhibitory concentration: > 1000 nM
Compound 3: only a limit was reported; the forecaster's own chance of this, stated with the estimate: 40%; at least 1.4-fold (0.15 log units) between middle value and limit.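

In this assay, 1H-benzimidazol-2-yl in place of furan-2-yl gives an at least 6.4-fold higher number from compound 1 to compound 3 (0.80 log units; beyond the scatter), so a second, larger group at this place also fails to keep the number of compound 1. Of the three compounds, only compound 1, with furan-2-yl, now has a measured number. The step between compound 2 and compound 3 cannot be read, and the two cannot be ordered, because both stand at a limit: the limit of > 1000 nM in this assay, at which 2 of the 3 values shown sit.

On these data alone, what remains open is how weak compound 2 and compound 3 really are, and whether an oxazol-2-yl or a phenyl group at this place would behave like furan-2-yl.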